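Swapping chlorine for fluorine on the diarylmethyl group

The source may hold more compounds than are shown below. What is called first, only, known or untested is meant among the compounds shown, and "the series" means these compounds.

Compound 1, `O=C(O)Cc1sc(C(c2ccccc2)c2ccc(Cl)cc2)nc1-c1ccc(Cl)cc1`, gives 80%.
Compound 2, `O=C(O)Cc1sc(C(c2ccccc2)c2ccc(Cl)cc2)nc1-c1ccc(F)cc1`, gives 80%.
Compound 3, `O=C(O)Cc1sc(C2COc3ccccc3O2)nc1-c1ccc(Cl)cc1`, gives 50%.

All three numbers come from an in vitro functional assay on HEK285-7 cells for antagonist activity at prostaglandin D2 receptor 2 (Homo sapiens), read by BRET and beta-arrestin recruitment; a lower number here means a smaller maximal response, a higher number a larger maximal response. Compound 1 stands level with compound 2, and the two share the larger of the values seen; compound 3 sits under both, its number lower than that of compound 1 by a gap beyond the usual scatter.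

The compound now in question is compound 4, `O=C(O)Cc1sc(C(c2ccccc2)c2ccc(F)cc2)nc1-c1ccc(Cl)cc1`, which differs from compound 1 in a single place: fluoro in place of chloro on an aromatic carbon. For the measured compounds named here, one measured step bears directly on this change: no change at the digits printed from compound 1 to compound 2 (within the scatter), the same swap of halogen made elsewhere on the shared core. That swap left the maximal response unchanged within the scatter, so the swap from compound 1 to compound 4 is expected to behave alike, giving no change at the digits printed from compound 1 to compound 4 (within the scatter), that is, no step beyond the scatter in either direction. Compound 3 alters a different part of the molecule and offers no guidance on this particular exchange.

Compound 4 is therefore estimated at 80%, expected to fall between 66% and 92%.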

Compound 4, largest response reached (reported as efficacy), in percent of the reference or control that the assay uses: 80%
Compound 4: the middle estimate sits on the measured number at the digits printed, and the stated range covers the measured number.
By their numbers in this assay, from the lowest: compound 3; then compounds 1, 2 and 4 (each within the scatter of the next).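

In this assay the exchange of 4-chlorophenyl to 4-fluorophenyl, made on the diarylmethyl group, gives no change at the digits printed from compound 1 to compound 4 (within the scatter) and so adds a second place to the one known before. For the compounds shown here, until now the only reading of this halogen swap was no change at the digits printed from compound 1 to compound 2 (within the scatter) on the other chlorinated ring, so nothing yet showed how the diarylmethyl position itself would answer. Chlorine and fluorine at this spot, para to a large group, now cannot be told apart by the largest response reached, although no other kind of measurement is available to explain that result.

These compounds leave open whether the two fluoro exchanges would still show no step beyond the scatter if both were present in one molecule, since each has been read only with chloro on the other ring. They also leave open how this position would answer to a group other than a halogen, such as methoxy, trifluoromethyl, a nitrile or an amine, which would show whether the level response extends past chloro and fluoro.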